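The source may hold more compounds than are shown below. What is called first, only, known or untested is meant among the compounds shown, and "the series" means these compounds.

Compound 1, `NC1=NC2(CCSCC2)N(OCCCOc2ccc(Cl)c(Cl)c2)C(N)=N1`, is the measured point from which this account starts. In an assay on isolated protein for inhibition of Dihydrofolate reductase (Homo sapiens), read by spectrophotometry, using NADPH, with stated times of 5 s and 6 min, tested at 5 uM (on this read-out lower numbers stand for a weaker effect and higher numbers for a stronger effect at the one concentration tested), compound 1 gives 88.4%, the top of the two numbers shown. For the measured compounds named here, the only other measured compound, compound 2, `NC1=NC2(CCOCC2)N(OCCCOc2cccc(Cl)c2Cl)C(N)=N1`, gives 81.7% in this assay, and the gap between the two lies within the usual scatter of repeated measurements, so the two cannot be told apart on these data. Compound 3, `NC1=NC2(CCSCC2)N(OCCCOc2cc(Cl)c(Cl)cc2Cl)C(N)=N1`, has not yet been measured in this assay. Compound 3 differs from compound 1 in one place: chloro in place of hydrogen on an aromatic carbon. No step between measured compounds is known here, and the two measured numbers sit close together at a high level of inhibition, so no shown step gives a direction for this change. The step from compound 1 to compound 3 is therefore expected to be small, a number 3.4 percentage points lower from compound 1 to compound 3 (within the scatter), with no change beyond the scatter in either direction. Compound 3 is estimated to give 85% in this assay, with a range from 68% to 96%.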

Compound 3, a percentage reported as inhibition, at one concentration (the size of the read-out at that concentration, not a potency): 84.4%
Beside the measured number, compound 3's estimate is 0.6 percentage points above it; low and high end bracket the measured number.
By their numbers in this assay, from the lowest: compounds 2, 3 and 1 (each within the scatter of the next).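

For the compounds shown here, the step from the 3,4-dichlorophenyl to the 2,4,5-trichlorophenyl group gives a number 4 percentage points lower from compound 1 to compound 3 (within the scatter) in this assay and is the first change in a single place that can be read. It shows that a chloro group can stand on this aromatic carbon, ortho to a large group, meta to a chloro group and para to a chloro group, without moving the read-out beyond the scatter at the one concentration tested. Nothing given here accounts for this outcome. The read-out is a percentage at one concentration and not a potency, so these compounds leave open whether compound 1 and compound 3 would still match across a range of concentrations. Also open, from the compounds shown here alone, is whether a group other than chloro on this same carbon, such as a methoxy group, an amine or a carboxylic acid, would leave the number in the same place, and whether the chloro step would read the same on the core of compound 2.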